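The source may hold more compounds than are shown below. What is called first, only, known or untested is meant among the compounds shown, and "the series" means these compounds.

Compound 1 `O=[N+]([O-])c1cc(O)c(/N=N/c2c(O)ccc3ccccc23)c2ccccc12`: < 5%
Compound 2 `O=C(Nc1c(O)cc(S(=O)(=O)O)c2ccccc12)c1c(O)ccc2ccccc12`: < 5%
Compound 3 `Cc1[nH]n(-c2cccc(C(F)(F)F)c2)c(=O)c1/N=N/c1c(O)cc(S(=O)(=O)O)c2ccccc12`: 62%

In an assay on BaF3 cells with thrombopoietin receptor (Homo sapiens) as the target, read by a luciferase reporter (a lower number here means a smaller maximal response, a higher number a larger maximal response), compound 1 reaches only a limit of the assay, < 5%. Compound 2 likewise stops at a limit, < 5%. Among the compounds with values here, compound 3 gives 62%, the only real number among the three. The two remaining values sit at the limit of < 5% in this assay, at which 2 of the 3 values shown sit. Compound 4 `Cc1[nH]n(-c2cc(Cl)c(S(=O)(=O)O)cc2Cl)c(=O)c1/N=N/c1c(O)cc(S(=O)(=O)O)c2ccccc12` has not yet been measured in this assay. It differs from compound 3 in one place: a group of 12 heavy atoms (6 carbon, 3 oxygen, 1 sulfur, 2 chlorine; one six-membered aromatic ring of carbon only) in place of a group of 10 heavy atoms (7 carbon, 3 fluorine; one six-membered aromatic ring of carbon only), on an aromatic nitrogen. Within the data shown here, no step between two measured compounds is available as a guide, so any expectation rests on compound 3 alone. The step of a number 17 percentage points lower from compound 3 to compound 4 (beyond the scatter) is expected to go downward by more than the usual scatter, though with wide uncertainty. Compound 4 is accordingly estimated at 45%, within a range from 10% to 80%.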

Compound 4, largest response reached (reported as efficacy), in percent of the reference or control that the assay uses: < 5%
Compound 4: only a limit was reported; the forecaster's own chance of this, stated with the estimate: 20%; middle value at least 40 percentage points away from the limit.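

In this assay, the group on the aromatic nitrogen strongly governs the maximal response: replacing 3-(trifluoromethyl)phenyl with the ring bearing two chlorines and a sulfonic acid gives a number at least 57 percentage points lower from compound 3 to compound 4 (beyond the scatter). The shared core with its azo link therefore does not secure a response by itself. The reading for compound 4 is a limit of the assay, not a number: the limit of < 5% in this assay, at which 3 of the 4 values shown sit.

The compounds shown do not separate the contribution of the chlorines from that of the sulfonic acid. Going by these compounds, how an unsubstituted phenyl, or a ring carrying a carboxylic acid or an amine, would behave at this position remains open.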